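Notes on the series, step from compound 3 to compound 4

This account rests on a few compounds, and the source may have more. Where it says the series, first, only, none or still open, it means among the compounds named here.

Measured so far in an assay on HEK293 cells for inhibition of solute carrier family 22 member 12 (Homo sapiens), read by scintillation counting, with a stated time of 12 min; on this read-out higher numbers stand for weaker inhibition and lower numbers for stronger inhibition:
Compound 1 `O=C(O)C1(Sc2ccnc3cccnc23)CCC1` gives > 10000 nM, which is a limit of the assay.
Compound 2 `O=C1COc2cccc(SC3(C(=O)O)CCC3)c2N1` gives > 10000 nM, which is a limit of the assay.
Compound 3 `N#CCCc1ccc2nccc(SC3(C(=O)O)CCC3)c2c1` gives 2760 nM.

Among the compounds with values here, compound 3 holds the only numerical value in this assay. Within the data shown here, the two other entries sit at the assay limit (the limit of > 10000 nM in this assay, at which 2 of the 3 values shown sit), so no step between measured compounds can be sized, and compound 3 is the sole anchor for the series.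

Compound 4 `CNC(=O)COc1ccc2nccc(SC3(C(=O)O)CCC3)c2c1` is not yet measured. It differs from compound 3 by (methylcarbamoyl)methoxy in place of 2-cyanoethyl on an aromatic carbon. The shared core and the acid are kept; only the group on an aromatic carbon of the fused system is exchanged. Among the measured compounds shown here, with no measured step of this kind to lean on, the expectation is cautious: a step from compound 3 to compound 4 of a 1.4-fold higher number from compound 3 to compound 4 (0.16 log units; within the scatter) is expected, small and toward weaker inhibition, not clearly beyond the scatter. Compound 4 is therefore estimated at 4000 nM, with a range from 1200 nM to 14000 nM; the upper end reaches the region where the assay reports only a limit.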

Compound 4, half-maximal inhibitory concentration: > 10000 nM
Compound 4 ended at the assay's limit (the forecaster's own chance of this, stated with the estimate: 30%); middle value at least 2.5-fold (0.39 log units) away from the limit.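

In this assay, exchanging 2-cyanoethyl for (methylcarbamoyl)methoxy on this aromatic carbon, with the shared core and the acid kept, gives an at least 3.6-fold higher number from compound 3 to compound 4 (0.55 log units; beyond the scatter), so this position is not indifferent to the group it carries. Compound 4 gives > 10000 nM, which is a limit of the assay. Compound 3 remains the only compound with a numerical value, and the series still offers just this one readable step: the limit of > 10000 nM in this assay, at which 3 of the 4 values shown sit.

Whether the ether oxygen, the amide or the length of the chain accounts for the step stays open, and a plain methoxy, a simple amine or a longer nitrile chain on the same aromatic carbon would help to separate these. Also open, going by these compounds, is whether any group at this position gives stronger inhibition than 2-cyanoethyl.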